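Cytotoxicity of Chalcone Amides: Propoxy Replaced by Trifluoromethyl

The source may hold more compounds than are shown below. What is called first, only, known or untested is meant among the compounds shown, and "the series" means these compounds.

Measured compounds:
Compound 1, `COC(=O)c1cc(-c2cccc(NC(=O)c3ccc(/C=C/C(=O)c4cc(OC)c(OC)c(OC)c4)cc3)c2)on1`, gives > 50 ug/mL in an ADME assay on Vero cells (Chlorocebus sabaeus) for cytotoxicity, read by MTT assay, with a stated time of 72 h (on this read-out lower numbers stand for higher toxicity in this test and higher numbers for lower toxicity in this test), which is a limit of the assay and not a number.
Compound 2, `CCCOc1ccc(C(=O)/C=C/c2ccc(C(=O)Nc3cccc(-c4cc(C(=O)OC)no4)c3)cc2)cc1`, gives > 40 ug/mL in this assay, again a limit and not a number.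

Within the data shown here, compound 2 thus stands at the limit of > 40 ug/mL in this assay, at which 1 of the 2 values shown sits, while compound 1 stands at the limit of > 50 ug/mL in this assay, at which 1 of the 2 values shown sits, and the one measured step between them, a step that the two limits leave unreadable from compound 1 to compound 2, has no readable size, both of its ends being limits.

Compound 3, `COC(=O)c1cc(-c2cccc(NC(=O)c3ccc(/C=C/C(=O)c4cccc(C(F)(F)F)c4)cc3)c2)on1`, differs from compound 2 in one place: 3-(trifluoromethyl)phenyl in place of 4-propoxyphenyl on a carbonyl carbon. Among the measured compounds shown here, the only measured step touching this carbonyl carbon is the one from compound 1 to compound 2, and it gives neither size nor direction, so the expectation can rest on nothing more than the two limits themselves.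

Compound 3 is therefore expected to show a step that the limit leaves unreadable from compound 2 to compound 3 of no size beyond the scatter, and most probably the assay will again return only a limit. The estimate for compound 3 is 50 ug/mL, within a range from 20 ug/mL to 100 ug/mL.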

Compound 3, half-maximal cytotoxic concentration: > 20 ug/mL
Compound 3: no number, only a limit; the forecaster's own chance of this, stated with the estimate: 70%; the middle value does not contradict the limit.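

In this assay compound 3 gives > 20 ug/mL, which is a limit of the assay and not a number. The steps joining compound 1 and compound 2 to compound 3 therefore cannot be read, since limits stand at both ends. The compounds shown leave open whether the group on the carbonyl carbon alters the half-maximal cytotoxic concentration at all.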